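The source may hold more compounds than are shown below. What is called first, only, known or untested is meant among the compounds shown, and "the series" means these compounds.

Measured compounds and their values:

compound 1, `CSc1[nH]ccc2ncnc1-2`: < 5%
compound 2, `CN(C)c1nccc2c1ncn2C1O[C@H](CO)[C@@H](O)[C@H]1O`: 10%
compound 3, `OCCNc1nccc2c1ncn2C1O[C@H](CO)[C@@H](O)[C@H]1O`: 6%

In a functional assay on EL4 cells (Mus musculus) for inhibition, tested at 100 uM (a lower number here means less inhibition, a higher number more inhibition at the concentration tested (going by the name of the read-out)), compound 1 gives only < 5%, which is a limit of the assay and not a number (the limit of < 5% in this assay, at which 1 of the 3 values shown sits). Compound 2 gives 10% and compound 3 gives 6% in the same assay. Among the compounds with values here, the one measured step, a number 4 percentage points lower from compound 2 to compound 3 (within the scatter), exchanges one amino substituent for another on a core that compounds 2 and 3 share but compound 1 does not.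

Compound 4, `CNc1[nH]ccc2ncnc1-2`, differs from compound 1 by methylamino in place of methylsulfanyl on an aromatic carbon. Within the data shown here, no measured step touches this exchange directly. Among the measured compounds shown here, the only step on hand, between compounds 2 and 3, is within the scatter, and all three values sit at or near the lower end of the read-out. Nothing here points to a step beyond the scatter for compound 4 in this assay. Compound 4 is therefore estimated at 5%, between 0% and 15%. The step of a number no lower from compound 1 to compound 4 (the limit leaves the size open) is the expected outcome.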

Compound 4, a percentage reported as inhibition, at one concentration (the size of the read-out at that concentration, not a potency): < 5%
Compound 4 ended at the assay's limit; the forecaster's own chance of this, stated with the estimate: 50%; the middle value sits exactly at the limit.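

Within the data shown here, compound 1 and compound 4 both stand at a limit of this assay rather than at a number, so no step between them can be read: the limit of < 5% in this assay, at which 2 of the 4 values shown sit. The compounds shown leave open whether methylamino in place of methylsulfanyl makes any difference to the inhibition.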